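The source may hold more compounds than are shown below. What is called first, only, known or untested is meant among the compounds shown, and "the series" means these compounds.

Measured compounds in a functional assay on PC-3 cells (Homo sapiens) for inhibition, read by sulforhodamine B assay, with a stated time of 48 h; a lower number here means that less compound is tolerated, a higher number that more compound is tolerated:
compound 1, `NS(=O)(=O)c1ccc(Nc2nc(N/N=C/c3ccc(C(F)(F)F)cc3)nc(Nc3ccccc3)n2)cc1`, gives 78500 nM.
compound 2, `Cc1nn(-c2ccccc2)cc1/C=N/Nc1nc(Nc2ccccc2)nc(Nc2ccc(S(N)(=O)=O)cc2)n1`, gives > 100000 nM, which is a limit of the assay and not a number.

Compound 2 therefore stands only at a bound on the numbers shown; this is the limit of > 100000 nM in this assay, at which 1 of the 2 values shown sits. Among the measured compounds shown here, the one step measured in this assay, an at least 1.2-fold higher number from compound 1 to compound 2 (0.10 log units; that floor lies within the scatter), concerns the aromatic group on the carbon with a double bond to nitrogen, and its floor lies within the scatter, so it cannot say how large the true change at that site is. Compound 3, `NS(=O)(=O)c1ccc(Nc2nc(N/N=C/c3ccccn3)nc(Nc3ccccc3)n2)cc1`, differs from compound 2 by pyridin-2-yl in place of 3-methyl-1-phenyl-1H-pyrazol-4-yl on a carbon with a double bond to nitrogen. For the measured compounds named here, since the only measured step at this carbon cannot be placed beyond the scatter, no step beyond the scatter is expected in this assay from exchanging one aromatic group for another here. Compound 3 is thus expected to lie near the same bound, at an estimated 100000 nM, within 40000 nM to 300000 nM. The step this estimate implies, a number no higher from compound 2 to compound 3 (the limit leaves the size open), is an expectation only, and a further limit reading is as likely as a number.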

Compound 3, concentration lethal to 50% of the cells: > 100000 nM
Compound 3 was reported as a limit; the forecaster's own chance of this, stated with the estimate: 50%; the middle value lies on the limit itself.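

In this assay compound 3 gives > 100000 nM, which is a limit of the assay and not a number. The carbon with a double bond to nitrogen now carries a second group that ends at this limit: pyridin-2-yl, a single six-membered aromatic ring, behaves in this respect like the larger 3-methyl-1-phenyl-1H-pyrazol-4-yl, and the step between compound 2 and compound 3 cannot be read. Set against 4-(trifluoromethyl)phenyl, the exchange gives an at least 1.2-fold higher number from compound 1 to compound 3 (0.10 log units; that floor lies within the scatter), so its true size stays open, and only compound 1 of the three carries a number, while the others rest on one bound: the limit of > 100000 nM in this assay, at which 2 of the 3 values shown sit.

On these data alone, whether a phenyl group bearing an amine or a carboxylic acid, or a plain alkyl chain in place of the aromatic group on this carbon, would bring the number clearly below that of compound 1 remains open. Also open, as far as these compounds go, is how far past the limit compound 2 and compound 3 truly lie, so the order of the three compounds at this carbon cannot yet be settled.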